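This account rests on a few compounds, and the source may have more. Where it says the series, first, only, none or still open, it means among the compounds named here.

Among the compounds with values here, compound 2 `O=Cc1c(Nc2ccccc2)oc2ccc(Cl)cc2c1=O` has the higher of the two numbers so far in a functional assay on PC-3 cells (Homo sapiens) for cytotoxicity, read by MTT assay, with a stated time of 48 h (a lower number here means that less compound is tolerated, a higher number that more compound is tolerated), where compound 2 gives 8300 nM. Its nearest neighbour is compound 1 `O=Cc1c(Nc2ccccc2)oc2ccccc2c1=O`, which in this assay gives 8200 nM; the two are within the scatter of each other, so neither can be called the more tolerated.

Compound 3 `O=Cc1c(Nc2ccccc2)oc2ccc(F)cc2c1=O` is the unmeasured partner. The change from compound 2 to compound 3 is fluoro in place of chloro on an aromatic carbon. Within the data shown here, only one measured step touches this position: a 1.0-fold higher number from compound 1 to compound 2 (0.01 log units; within the scatter), in which chloro took the place of hydrogen on the same aromatic carbon without moving the number. With a halogen already sitting there and making no difference, swapping one halogen for another at the same place is expected to leave this assay essentially unchanged, with no step beyond the scatter in either direction.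

Compound 3 is therefore expected to come out at about 8300 nM, with a likely range from 4000 nM to 17000 nM, which means an estimated step of no change at the digits printed from compound 2 to compound 3 (within the scatter).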

Compound 3, concentration lethal to 50% of the cells: 8600 nM
The estimate for compound 3 lay 1.0-fold (0.02 log units) below the measured number; the measured number falls inside the stated range.
By their numbers in this assay, from the lowest: compounds 1, 2 and 3 (each within the scatter of the next).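

Swapping chloro for fluoro on this aromatic carbon gives, in this assay, a 1.0-fold higher number from compound 2 to compound 3 (0.02 log units; within the scatter) and so adds a comparison of one halogen with another, which the earlier pair could not offer. Fluoro in place of hydrogen on the same carbon gives a 1.0-fold higher number from compound 1 to compound 3 (0.02 log units; within the scatter) and, together with the earlier chloro step, this places hydrogen, chloro and fluoro all within the scatter of one another on the shared core, so in these three compounds the choice among the three groups makes no readable difference to how much compound the cells tolerate. No measurement is available to say why the number stays put when this position changes.

Going by these compounds, each group seen at this carbon is a single atom, so it remains open whether a group of several atoms there, such as methoxy, an amine or a carboxylic acid, would move the number beyond the scatter. All three compounds also share everything else on the core, which leaves open what a change elsewhere would do, for instance a nitrile in place of the aldehyde or a substituent on the phenyl ring of the aniline.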